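The source may hold more compounds than are shown below. What is called first, only, known or untested is meant among the compounds shown, and "the series" means these compounds.

Compound 1 `COc1ccc2c(=O)c(Cc3ccccc3)c(C)[nH]c2c1` and compound 2 `COc1cccc2[nH]c(C)c(Cc3ccccc3)c(=O)c12` are built from the same atoms joined differently; the difference between the two cores is not broken down here. In a physicochemical assay for lipophilicity, at pH 7.4 (on this read-out higher numbers stand for higher lipophilicity and lower numbers for lower lipophilicity), compound 1 gives 2.52 and compound 2 gives 2.11, the lowest of the three measured numbers. Compound 3 `Cc1[nH]c2cc(Cl)ccc2c(=O)c1Cc1ccccc1` carries chloro in place of methoxy on an aromatic carbon; in this assay compound 3 gives 2.69, a step of a number 0.17 log units higher from compound 1 to compound 3 (within the scatter). Compound 4 `Cc1[nH]c2cccc(Cl)c2c(=O)c1Cc1ccccc1`, not yet measured, carries chloro in place of methoxy on an aromatic carbon, the same kind of change, though its place is ortho to a fused ring and meta to a fused ring rather than meta and para. Given the measured step of a number 0.17 log units higher from compound 1 to compound 3 (within the scatter), the expected step is a number 0.24 log units higher from compound 2 to compound 4 (within the scatter). Compound 4 is therefore estimated at 2.35, likely between 2 and 2.7.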

Compound 4, distribution coefficient: 2.65
Compound 4: middle estimate off by 0.30 log units, on the low side, within the range that was stated.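

In this assay, chloro in place of methoxy on an aromatic carbon gives a number 0.54 log units higher from compound 2 to compound 4 (beyond the scatter) on the core of compound 2, while the same kind of change gives a number 0.17 log units higher from compound 1 to compound 3 (within the scatter) on the core of compound 1. The step therefore lies beyond the scatter in one case and within it in the other, which shows that the first result alone did not settle the second, though the group's place differs as well as the core. Among the compounds shown here, with only one pair on each core, this sets no rule for the series, and nothing here explains the contrast. As far as these compounds go, an amine or a carboxylic acid in the same place remains open. So does whether a longer chain in place of methoxy would behave alike on both cores.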